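Methoxy to Hydroxy on a Diaryl Diyne Growth Inhibitor

The source may hold more compounds than are shown below. What is called first, only, known or untested is meant among the compounds shown, and "the series" means these compounds.

Of the compounds shown here, two have been tested for their effect on cell growth. Compound 1 `OCCCCC#Cc1ccccc1C#Cc1cccs1` and compound 2 `COc1cccc(C#Cc2ccccc2C#CCCCCO)c1` share a core bearing a hydroxypentynyl chain and differ only in the aromatic group at the far end. In a functional assay on MDA-MB-435 cells (Homo sapiens) for cytotoxicity (a lower number here means a stronger inhibitor of growth, a higher number a weaker inhibitor of growth), compound 1 gives 16600 nM, and in this assay compound 2 gives 1900 nM. Compound 2 therefore has the lowest number of the two, and its gap to compound 1 is beyond the scatter, so compound 2 is the stronger of the pair.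

Compound 3 `OCCCCC#Cc1ccccc1C#Cc1cccc(O)c1` comes from compound 2 by a single change: hydrogen in place of methyl on an oxygen on an aromatic ring, that is, methoxy becomes hydroxy. Among the compounds with values here, no comparable step between measured compounds exists, so the likely size is uncertain. A small change within the scatter is expected, with the number for compound 3 estimated at 3000 nM, ranging from 1000 nM to 9000 nM. The expected step is a 1.6-fold higher number from compound 2 to compound 3 (0.20 log units; within the scatter).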

Compound 3, concentration for 50% growth inhibition: 16100 nM
Compound 3: middle estimate off by 5.4-fold (0.73 log units), on the low side; measured number above the stated range.
By their numbers in this assay, from the lowest: compound 2; then compounds 3 and 1 (each within the scatter of the next).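

In this assay, hydrogen in place of methyl on this aromatic oxygen gives an 8.5-fold higher number from compound 2 to compound 3 (0.93 log units; beyond the scatter), so this single change removes the lead that compound 2 held, and the methyl on that oxygen clearly matters to growth inhibition. Exchanging the group on the triple-bonded carbon gives a 1.0-fold lower number from compound 1 to compound 3 (0.01 log units; within the scatter), so 3-hydroxyphenyl and thiophen-2-yl in these two compounds cannot be told apart in this test. Nothing measured here explains the size of the methoxy to hydroxy step.

From the compounds shown here alone, it remains open whether ethoxy or an amine in place of methoxy would keep the growth inhibition seen with compound 2. The compounds shown also leave open whether methoxy on the thiophene ring, or a longer chain carrying the hydroxy group, would shift the number.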